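A few compounds are considered here, and "the series" means these few. Any claim that something is new, unique, unknown or untested is made for them only; others in the source may bear on it.

Series notes, aryl ether variation on the shared core.

Compound 1 `CN1CCN(c2nc(N)nc(COc3ccccc3)n2)CC1` serves as the parent; in an assay on HEK293 cells for displacement of a labelled ligand from 5-hydroxytryptamine receptor 7 (Homo sapiens), read by radioligand binding, with a stated time of 1 h (a higher number here means a weaker inhibitor, a lower number a stronger inhibitor), compound 1 gives 9530 nM. Compound 2 `CN1CCN(c2nc(N)nc(COc3ccccc3Cl)n2)CC1` carries a chloro group on the aryl ether, and in this assay compound 2 gives 9250 nM; the step from the parent is a 1.0-fold lower number from compound 1 to compound 2 (0.01 log units; within the scatter). Compound 3 `CN1CCN(c2nc(N)nc(COc3cccc(Cl)c3)n2)CC1` places the chloro group differently, and in this assay compound 3 gives 5820 nM, with a 1.6-fold lower number from compound 1 to compound 3 (0.21 log units; within the scatter) and a 1.6-fold lower number from compound 2 to compound 3 (0.20 log units; within the scatter). Compound 3 thus sits with compounds 1 and 2 inside the usual scatter; no ordering among the three is supported by these numbers.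

Compound 4 `Cc1ccccc1OCc1nc(N)nc(N2CCN(C)CC2)n1` is the next member, not yet measured in this assay. The change from compound 3 is 2-methylphenyl in place of 3-chlorophenyl on an oxygen on a saturated carbon. For the measured compounds named here, the steps that bear on it are the aryl substitution steps already seen: a 1.6-fold lower number from compound 2 to compound 3 (0.20 log units; within the scatter), which moved the chloro group between two positions of the phenyl ring, and a 1.6-fold lower number from compound 1 to compound 3 (0.21 log units; within the scatter) and a 1.0-fold lower number from compound 1 to compound 2 (0.01 log units; within the scatter), which introduced it. None of the three exceeded the scatter. A substituent swap on the same phenyl ring is therefore expected to give no step beyond the scatter in this assay, with no preferred direction, so the expected step is a 1.4-fold higher number from compound 3 to compound 4 (0.14 log units; within the scatter). Compound 4 is estimated at 8000 nM, in the range 4000 nM to 16000 nM.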

Compound 4, inhibition constant: 514 nM
For compound 4 the middle estimate is 16-fold (1.19 log units) above the measured one; measured number below the stated range.
By their numbers in this assay, from the lowest: compound 4; then compounds 3, 2 and 1 (each within the scatter of the next).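

In this assay the group on the oxygen on a saturated carbon proves able to move the number well beyond the scatter, which none of the three earlier compounds showed: a methyl group on the phenyl ring gives a 19-fold lower number from compound 1 to compound 4 (1.27 log units; beyond the scatter) whereas chloro in place of hydrogen gave no step beyond the scatter in compound 2 or compound 3. The gain is tied to the methyl group rather than to substitution of the phenyl ring as such, since methyl in place of chloro on an aromatic carbon gives an 18-fold lower number from compound 2 to compound 4 (1.26 log units; beyond the scatter) and 2-methylphenyl in place of 3-chlorophenyl gives an 11-fold lower number from compound 3 to compound 4 (1.05 log units; beyond the scatter). Compound 2 and compound 3 stand against any general effect of a substituent on this ring. No measurement at hand explains why methyl and chloro part so sharply here.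

The compounds shown leave open whether 3-methylphenyl would keep the step, which would separate the identity of the group from its place on the ring. Also open, going by these compounds, is whether an ethyl, methoxy or amino group on the phenyl ring would match the methyl group of compound 4.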